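From naphthalen-1-yl to phenyl on compound 3

The source may hold more compounds than are shown below. What is called first, only, known or untested is meant among the compounds shown, and "the series" means these compounds.

- compound 1 `COc1ccc(S(=O)(=O)Oc2ccccc2/C=C(\C#N)C(=O)Nc2nnc(Cc3cccc4ccccc34)s2)cc1` gives 78%
- compound 2 `N#C/C(=C\c1ccccc1OS(=O)(=O)c1ccc(Cl)cc1)C(=O)Nc1nnc(Cc2cccc3ccccc23)s1` gives 68%
- compound 3 `N#C/C(=C\c1ccccc1OS(=O)(=O)c1ccc(F)cc1)C(=O)Nc1nnc(Cc2cccc3ccccc23)s1` gives 68%

These numbers come from a functional assay on RS4-11 cells (Homo sapiens) for inhibition, read by CCK-8 assay, with a stated time of 48 h, tested at 20 uM (on this read-out higher numbers stand for more inhibition of growth at the one concentration tested and lower numbers for less inhibition of growth), and compound 3 stands level with compound 2, with compound 1 also within the scatter. Compound 4 `N#C/C(=C\c1ccccc1OS(=O)(=O)c1ccc(F)cc1)C(=O)Nc1nnc(Cc2ccccc2)s1` keeps the rest of compound 3 but carries phenyl in place of naphthalen-1-yl on a saturated chain carbon bound to an aromatic carbon. Going by the values given here, no measured step touches this place. The nearest guides, a number 10 percentage points lower from compound 1 to compound 3 (within the scatter) and no change at the digits printed from compound 2 to compound 3 (within the scatter), concern a different aromatic carbon, so they say little here. The expected shift in this assay is a number 12 percentage points lower from compound 3 to compound 4 (beyond the scatter) and it is a cautious guess. For compound 4 the estimate is 56% with an expected range from 32% to 76%.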

Compound 4, percent growth inhibition at one concentration: 69%
Compound 4: middle estimate off by 13 percentage points, on the low side, within the range that was stated.
By their numbers in this assay, from the lowest: compounds 2, 3, 4 and 1 (each within the scatter of the next).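

In this assay, going by these compounds alone, the first change at this position gives a number 1 percentage points higher from compound 3 to compound 4 (within the scatter). For this pair, the second aromatic ring of naphthalen-1-yl is not needed to keep growth inhibition at the one concentration tested, and phenyl serves as well. Nothing shown explains this result.

On these data alone, it remains open whether a carboxylic acid or an amine on the phenyl ring, or a longer chain carrying it, would keep this level. As far as these compounds go, it is also open whether the same swap would behave alike on compound 1, which carries methoxy instead of fluoro.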